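A Chloro Substituent on the Ring of a Tetrazolyl Amide

The source may hold more compounds than are shown below. What is called first, only, known or untested is meant among the compounds shown, and "the series" means these compounds.

Compounds measured so far:
compound 1, `O=C(Nc1nnn[nH]1)c1cc(=O)c2ccccc2o1`: 100%
compound 2, `CN(C(=O)c1cc(=O)c2ccccc2o1)c1nnn[nH]1`: 0%
compound 3, `O=C(O)CCCNC(=O)c1cc(=O)c2ccccc2o1`: 0%

The three measured compounds share one core and differ only at the amide nitrogen. In a functional assay on the whole organism for inhibition, with Rattus norvegicus as the target, with a stated time of 30 min, at a dose of 1 mg/kg by the intravenous route (a higher number here means more inhibition at the dose given (going by the name of the read-out), a lower number less inhibition), compound 1 gives 100%, the highest of the three numbers. The two steps away from it are both large: a number 100 percentage points lower from compound 1 to compound 2 (beyond the scatter), and a number 100 percentage points lower from compound 1 to compound 3 (beyond the scatter). Compound 2 and compound 3 sit together at the bottom and their two values show no difference between them.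

Compound 4, `O=C(Nc1nnn[nH]1)c1cc(=O)c2cc(Cl)ccc2o1`, keeps the amide and the tetrazolyl group of compound 1 unchanged and differs from it in a single place: chloro in place of hydrogen on an aromatic carbon. The change sits on an aromatic carbon of a six-membered aromatic ring of carbon only, part of a fused or bridged system of two rings, far from the amide nitrogen where the two measured steps occurred. Neither measured step therefore bears on this change; both concern the amide nitrogen and say nothing about the aromatic ring. With no evidence against the substitution, compound 4 is expected to stay close to compound 1, and the expected step of a number 10 percentage points lower from compound 1 to compound 4 (within the scatter) is small, if any, with a possible decline. The estimate for compound 4 in this assay is 90%, between 60% and 100%.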

Compound 4, a percentage reported as inhibition, in the whole organism at one dose (the size of the read-out at that dose, not a potency): 65%
Estimate against measurement, compound 4: 25 percentage points above; the measured number falls inside the stated range.
By their numbers in this assay, from the lowest: compounds 2 and 3 (each within the scatter of the next); then compound 4; then compound 1.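

The ring of the shared core, which neither earlier step touched, proves sensitive to substitution in this assay: chloro in place of hydrogen on an aromatic carbon gives a number 35 percentage points lower from compound 1 to compound 4 (beyond the scatter), even though the amide and the tetrazolyl group stay exactly as they were. This single added heavy atom, on a carbon far from the amide nitrogen, is thus enough to produce a large step, and activity is therefore not governed by the amide nitrogen alone, although compound 4 still gives 65% at the dose given. Nothing available explains why this substitution lowers the number.

The compounds shown leave open whether the lower number belongs to chloro in particular or would follow any group at this aromatic carbon, a question that fluoro, methyl or methoxy in the same place would address. They also leave open how chloro or an amine would fare on the other aromatic carbons of this ring, and so whether this position differs from the rest of the ring at all.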